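This account rests on a few compounds, and the source may have more. Where it says the series, first, only, none or still open, it means among the compounds named here.

Compound 1 `CCc1ccc(Nc2cc(NC(=O)Nc3cc(OC)cc(OC)c3)ncn2)cc1` in a functional assay on NCI-H520 cells (Homo sapiens) for inhibition, read by MTT assay, with a stated time of 48 h, tested at 10 uM (on this read-out lower numbers stand for less inhibition and higher numbers for more inhibition at the one concentration tested (going by the name of the read-out)), gives 23.5%. Compound 2 `COc1cc(NC(=O)Nc2cc(Nc3ccc(C)c(C)c3)ncn2)cc(OC)c1` gives 29.5%. Compound 3 `COc1cc(Br)ccc1Nc1cc(NC(=O)Nc2c(Cl)cccc2Cl)ncn1` gives 29.1%.

Compound 3 stands second highest of the three numbers, yet its gaps to compound 2 and to compound 1 both lie within the scatter, so all three sit at one level. Compound 4 `COc1cc(NC(=O)Nc2cc(Nc3ccc(Br)cc3OC)ncn2)cc(OC)c1` differs from compound 3 by 3,5-dimethoxyphenyl in place of 2,6-dichlorophenyl on an amide-type nitrogen. Within the data shown here, the one measured step, a number 6 percentage points higher from compound 1 to compound 2 (within the scatter), swaps a group on a different nitrogen and lies within the scatter; no measured step exchanges the group on the amide-type nitrogen. Compound 1 and compound 2 already carry the entering 3,5-dimethoxyphenyl and sit at the same level as compound 3. Compound 4 is expected to show a step of a number 1.1 percentage points lower from compound 3 to compound 4 (within the scatter) of no size beyond the scatter. The estimate for compound 4 is 28%, between 15% and 42%.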

Compound 4, a percentage reported as inhibition, at one concentration (the size of the read-out at that concentration, not a potency): 36.1%
Compound 4: the middle estimate sits 8.1 percentage points below what was measured; measured number inside the range.
By their numbers in this assay, from the lowest: compounds 1, 3, 2 and 4 (each within the scatter of the next, the first and the last beyond it).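

On the amide-type nitrogen, the first measured exchange, 3,5-dimethoxyphenyl in place of 2,6-dichlorophenyl, gives a number 7 percentage points higher from compound 3 to compound 4 (within the scatter) and so does not move the number clearly. On the nitrogen on an aromatic ring, 4-bromo-2-methoxyphenyl gives a number 6.6 percentage points higher from compound 2 to compound 4 (within the scatter) when it replaces 3,4-dimethylphenyl, but a number 12.6 percentage points higher from compound 1 to compound 4 (beyond the scatter) when it replaces 4-ethylphenyl. No measurement is at hand that would explain these steps. Still open, as far as these compounds go, is how a group with an amine, such as 4-aminophenyl, or a carboxylic acid would read on the amide-type nitrogen.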